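Adding a hydroxy group to a benzimidazole-type inhibitor

A few compounds are considered here, and "the series" means these few. Any claim that something is new, unique, unknown or untested is made for them only; others in the source may bear on it.

Measured compounds:
Compound 1 `FC(F)(F)c1ccc2[nH]c(-c3ccccc3)nc2c1` gives 75.6% in a functional assay on aorta (Rattus norvegicus, strain Wistar) for inhibition, with a stated time of 60 min; a lower number here means a smaller maximal response, a higher number a larger maximal response.
Compound 2 `CC(C)Oc1ccccc1-c1nc2cc([N+](=O)[O-])ccc2[nH]1` gives 31.7% in this assay.
Compound 3 `COc1cc(-c2nc3cc(C(F)(F)F)ccc3[nH]2)ccc1O` gives 97.7% in this assay.

Among these three, compound 1 stands second highest: compound 3 lies above it by a gap beyond the scatter, and compound 2 lies below it by a larger gap, also beyond the scatter. Compound 4 `Oc1ccc(-c2nc3cc(C(F)(F)F)ccc3[nH]2)cc1` has not yet been measured. It differs from compound 1 by hydroxy in place of hydrogen on an aromatic carbon. Within the data shown here, compound 3, which also carries a hydroxy group on the outer ring, gives the largest maximal response of the three, so a rise beyond the scatter is expected here, though the single added group in compound 4 need not reach as far. Compound 4 is estimated to give 88% (range 72% to 100%), a step of a number 12.4 percentage points higher from compound 1 to compound 4 (beyond the scatter).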

Compound 4, largest response reached (Emax), in percent of the reference or control that the assay uses: 37%
Beside the measured number, compound 4's estimate is 51 percentage points above it; measured number below the stated range.
By their numbers in this assay, from the lowest: compounds 2 and 4 (each within the scatter of the next); then compound 1; then compound 3.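

Hydroxy in place of hydrogen on this aromatic carbon, para to a large group, gives in this assay a drop, a number 38.6 percentage points lower from compound 1 to compound 4 (beyond the scatter), so the added hydroxy lowers the maximal response rather than raising it. With hydroxy kept, hydrogen in place of methoxy gives a number 60.7 percentage points lower from compound 3 to compound 4 (beyond the scatter), which ties the high response of compound 3 to the methoxy group and not to hydroxy alone.

No measurement shown explains this fall. As far as these compounds go, whether an amine or a carboxylic acid on this same carbon would also lower the response stays open.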